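This account rests on a few compounds, and the source may have more. Where it says the series, first, only, none or still open, it means among the compounds named here.

Working notes on the series. In a functional assay on SiHa cells (Homo sapiens) for antiproliferative activity, read by CCK-8 assay, with a stated time of 72 h (on this read-out higher numbers stand for weaker inhibition and lower numbers for stronger inhibition), compound 1 (`COc1ccc(-c2cncnc2-c2cc(OC)c(OC)c(OC)c2)cc1`) gives 2850 nM and compound 3 (`COc1cc(-c2ncncc2-c2ccc(C(=O)N(C)C)cc2)cc(OC)c1OC`) gives 20200 nM, the higher of the two numbers. Compound 2 (`COc1cc(-c2ncncc2-c2ccc(C(N)=O)cc2)cc(OC)c1OC`) reads > 100000 nM, which is a limit of the assay. Compound 4 (`COc1cc(-c2ncncc2-c2ccc(B(O)O)cc2)cc(OC)c1OC`) differs from compound 3 on an aromatic carbon: a group of 3 heavy atoms (1 boron, 2 oxygen; no ring) in place of a group of 5 heavy atoms (3 carbon, 1 nitrogen, 1 oxygen; no ring), on an aromatic carbon. The steps bearing on this change are made at the same carbon: an at least 35-fold higher number from compound 1 to compound 2 (1.54 log units; beyond the scatter), large, and a 7.1-fold higher number from compound 1 to compound 3 (0.85 log units; beyond the scatter), modest. Within the amide pair, an at least 4.9-fold lower number from compound 2 to compound 3 (0.69 log units; beyond the scatter) is at least modest. With only these steps as a guide, a modest move to a lower number is expected, with wide uncertainty: a 3.4-fold lower number from compound 3 to compound 4 (0.53 log units; beyond the scatter). For compound 4 the estimated value is 6000 nM, with an expected range from 500 nM to 50000 nM.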

Compound 4, half-maximal inhibitory concentration: 17500 nM
Estimate against measurement, compound 4: 2.9-fold (0.46 log units) below, and the stated range covers the measured number.
By their numbers in this assay, from the lowest: compound 1; then compounds 4 and 3 (each within the scatter of the next). At a limit, above all of these: compound 2.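

At this aromatic carbon, para to a large group, the boronic acid and the dimethylcarbamoyl group cannot be told apart in this assay: a 1.2-fold lower number from compound 3 to compound 4 (0.06 log units; within the scatter). The boronic acid does not match methoxy, a 6.1-fold higher number from compound 1 to compound 4 (0.79 log units; beyond the scatter), so none of the three replacements shown reaches compound 1. The step of an at least 5.7-fold lower number from compound 2 to compound 4 (0.75 log units; beyond the scatter) gives only a bound, as compound 2 reads at a limit: the limit of > 100000 nM in this assay, at which 1 of the 4 values shown sits.

As far as these compounds go, whether a carboxylic acid or a primary amine at this carbon would come closer to methoxy stays open. The compounds shown give no reason why the boronic acid and the dimethylcarbamoyl group read alike.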